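The source may hold more compounds than are shown below. What is called first, only, known or untested is meant among the compounds shown, and "the series" means these compounds.

Measured so far in a functional assay on Jurkat cells (Homo sapiens) (on this read-out higher numbers stand for weaker inhibition and lower numbers for stronger inhibition), are these compounds:
- compound 1 `C[C@H](NC(=O)C(=O)NCCC1CCCC1)C(=O)N[C@@H](CC(=O)O)C(=O)COc1c(F)c(F)cc(F)c1F` gives 11 nM
- compound 2 `C[C@H](NC(=O)C(=O)NCC1CCCCC1)C(=O)N[C@@H](CC(=O)O)C(=O)COc1c(F)c(F)cc(F)c1F` gives 19 nM
- compound 3 `Cc1ccc(CNC(=O)C(=O)N[C@@H](C)C(=O)N[C@@H](CC(=O)O)C(=O)COc2c(F)c(F)cc(F)c2F)cc1` gives 50 nM

Compound 3 has the highest number of the three, which makes it the weakest inhibitor here. The measured steps to it are a 2.6-fold higher number from compound 2 to compound 3 (0.42 log units; beyond the scatter) and a 4.5-fold higher number from compound 1 to compound 3 (0.66 log units; beyond the scatter) in this series.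

Compound 4 `Cc1cccc(CNC(=O)C(=O)N[C@@H](C)C(=O)N[C@@H](CC(=O)O)C(=O)COc2c(F)c(F)cc(F)c2F)c1C` has not yet been measured. It carries 2,3-dimethylphenyl in place of 4-methylphenyl on a saturated chain carbon bound to an amide-type nitrogen.

For the measured compounds named here, no measured step changes the methyl groups on this aromatic ring, so the evidence is indirect. The nearest guides are the steps at the same place, all of them swaps of the whole group. One is a 1.7-fold higher number from compound 1 to compound 2 (0.24 log units; within the scatter) and lies within the scatter, while the two steps into compound 3 are modest. Even these larger swaps stayed modest, so a smaller edit of the same group is expected to move the number little, and the data give no firm direction.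

The step expected in this assay is estimated as a 1.3-fold lower number from compound 3 to compound 4 (0.10 log units; within the scatter) and so stays within the scatter. For compound 4 the expected value is 40 nM with an estimated range from 13 nM to 120 nM in this assay.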

Compound 4, half-maximal inhibitory concentration: 102 nM
Beside the measured number, compound 4's estimate is 2.6-fold (0.41 log units) below it; measured number inside the range.
By their numbers in this assay, from the lowest: compounds 1 and 2 (each within the scatter of the next); then compound 3; then compound 4.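

In this assay, for the compounds shown here, the earlier steps at this place were all swaps of the whole group, and this one shows that changing only the methyl groups on the aromatic ring can already go beyond the scatter, with a 2.0-fold higher number from compound 3 to compound 4 (0.31 log units; beyond the scatter) on moving from 4-methylphenyl to 2,3-dimethylphenyl. The gap to the saturated groups also widens, to a 5.4-fold higher number from compound 2 to compound 4 (0.73 log units; beyond the scatter) against cyclohexyl and a 9.3-fold higher number from compound 1 to compound 4 (0.97 log units; beyond the scatter) against cyclopentylmethyl, so both aromatic compounds carry higher numbers than both saturated ones and compound 4 is the weakest inhibitor of the four. Nothing measured here tells why the number rises with this change.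

Compound 4 differs from compound 3 both in how many methyl groups the ring carries and in where they sit, and these four compounds cannot separate the two effects. Also open, as far as these compounds go, is how a plain phenyl with no methyl, or a ring bearing an amine or a carboxylic acid, would behave at this place, and whether any aromatic group can match the saturated ones.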